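Replacing the aryl amine in compound 1 with diisopropylamine

The source may report more compounds than this note shows. Statements on the series, on what has been measured and on what is new or still open speak of the compounds shown alone.

Three nucleoside analogues sharing one core have been measured in a functional assay on HL-60 cells (Homo sapiens) for inhibition, with a stated time of 72 h; on this read-out higher numbers stand for weaker inhibition and lower numbers for stronger inhibition. Compound 1, `CN(Cc1ncnc2c1ncn2[C@@H]1O[C@H](CO)[C@@H](O)[C@H]1O)c1ccccc1`, gives 4000 nM. Compound 2, `OC[C@H]1O[C@@H](n2cnc3c(Cn4ccc5ccccc54)ncnc32)[C@H](O)[C@@H]1O`, gives 5700 nM. Compound 3, `OC[C@H]1O[C@@H](n2cnc3c(COc4ccccn4)ncnc32)[C@H](O)[C@@H]1O`, gives 12000 nM. Among these three numbers compound 1 has the lowest; its nearest neighbour is compound 2, with a 1.4-fold higher number from compound 1 to compound 2 (0.15 log units; within the scatter), and the furthest is compound 3, with a 3.0-fold higher number from compound 1 to compound 3 (0.48 log units; beyond the scatter). Between the other two, a 2.1-fold higher number from compound 2 to compound 3 (0.32 log units; beyond the scatter).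

Compound 4, `CC(C)N(Cc1ncnc2c1ncn2[C@@H]1O[C@H](CO)[C@@H](O)[C@H]1O)C(C)C`, differs from compound 1 in one place: diisopropylamino in place of methyl(phenyl)amino on a saturated chain carbon bound to an aromatic carbon. Every measured step here also exchanges the group on the saturated chain carbon bound to an aromatic carbon, so all three bear on this one. They range from a change within the scatter to a modest weakening, and none exceeds a modest size. The new group, diisopropylamino, brings no ring where each measured group carried one, so the step is expected to fall toward the weaker end of what has been seen rather than to strengthen inhibition. Compound 4 is therefore expected to give 7000 nM in this assay, with a range from 2500 nM to 20000 nM, meaning an expected step of a 1.8-fold higher number from compound 1 to compound 4 (0.24 log units; within the scatter).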

Compound 4, half-maximal inhibitory concentration: 13000 nM
Compound 4: middle estimate off by 1.9-fold (0.27 log units), on the low side, within the range that was stated.
By their numbers in this assay, from the lowest: compounds 1 and 2 (each within the scatter of the next); then compounds 3 and 4 (each within the scatter of the next).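

In this assay, among these compounds, compound 4 is the first compound here with no ring in the group on the saturated chain carbon bound to an aromatic carbon, and the exchange of methyl(phenyl)amino for diisopropylamino carries a cost beyond the scatter (a 3.3-fold higher number from compound 1 to compound 4 (0.51 log units; beyond the scatter)), as does the exchange of 1H-indol-1-yl for diisopropylamino (a 2.3-fold higher number from compound 2 to compound 4 (0.36 log units; beyond the scatter)). A ring in this group is nevertheless not enough to keep the lower numbers: compound 3 carries one and goes against that pattern, since (pyridin-2-yl)oxy and diisopropylamino cannot be told apart (a 1.1-fold higher number from compound 3 to compound 4 (0.03 log units; within the scatter)). Nothing in the available data accounts for these differences.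

The compounds shown leave open whether a saturated ring amine such as piperidin-1-yl would read with compound 1 or with compound 4, which would separate the loss of the ring from the loss of its aromatic character. They also leave open whether a smaller amine such as dimethylamino would behave like diisopropylamino, so the role of the size of the chains on the nitrogen remains unsettled.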